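Hexyl to allyl: an estimate for compound 3

The source may hold more compounds than are shown below. What is called first, only, known or untested is meant among the compounds shown, and "the series" means these compounds.

Compounds in a functional assay on HCT-116 cells (Homo sapiens) for cytotoxicity, read by MTT assay, with a stated time of 48 h; on this read-out lower numbers stand for stronger inhibition and higher numbers for weaker inhibition
- compound 1 `CCCCCCOc1ccc2c(Cl)ccnc2c1` gives 2440 nM
- compound 2 `Clc1ccnc2cc(OCCc3ccccc3)ccc12` gives 2180 nM
- compound 3 `C=CCOc1ccc2c(Cl)ccnc2c1` is not yet measured

Compound 1 has only compound 2 for comparison, and the two cannot be told apart. Within the data shown here, the single measured step is a 1.1-fold lower number from compound 1 to compound 2 (0.05 log units; within the scatter), with phenyl in place of butyl on a saturated chain carbon, two bonds along the chain from an oxygen on an aromatic ring.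

Compound 3 differs from compound 1 as follows: vinyl in place of pentyl on a saturated chain carbon bound to an oxygen on an aromatic ring. This puts vinyl in place of pentyl on a saturated chain carbon bound to an oxygen on an aromatic ring, and cut one bond further out it reads hexyl to allyl.

Among the measured compounds shown here, the step to compound 2 is the only evidence that bears on this change, and it does not test a shorter group. For the measured compounds named here, no other measured compound does so either. No step beyond the scatter is therefore expected in this assay, although the range is left wider towards higher numbers. The expected step is a 1.2-fold higher number from compound 1 to compound 3 (0.09 log units; within the scatter). Compound 3 is estimated at 3000 nM, with an expected range of 1200 nM to 7500 nM.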

Compound 3, half-maximal inhibitory concentration: 2570 nM
The estimate for compound 3 lay 1.2-fold (0.07 log units) above the measured number; the measured number falls inside the stated range.
By their numbers in this assay, from the lowest: compounds 2, 1 and 3 (each within the scatter of the next).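

The move from hexyl to allyl in this assay stays within the scatter (a 1.1-fold higher number from compound 1 to compound 3 (0.02 log units; within the scatter)), with vinyl in place of pentyl on a saturated chain carbon bound to an oxygen on an aromatic ring. Among these compounds, this is the first test of a shorter group at this position: 2 heavy atoms enter where 5 leave, together with 1 double bond outside aromatic rings, and the read-out does not separate compound 3 from compound 1. With compound 2 already within the scatter of compound 1, the hexyl, phenyl-bearing and allyl groups on the oxygen of the shared core now stand as one flat set in this assay, and the measurements on hand offer no explanation for that flatness.

Still open, as far as these compounds go, is whether any group on this oxygen can move the number beyond the scatter, as an amine or a carboxylic acid at the end of the chain, or a chain longer than hexyl, might or might not do. Equally open is how much of the shared reading depends on the chlorine of the core, which stays the same in every compound shown here.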